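The source may hold more compounds than are shown below. What is called first, only, known or untested is meant among the compounds shown, and "the series" means these compounds.

Measured compounds in this series:
compound 1 `Oc1ccccc1CNc1ccc(-c2cccc(F)c2)cc1` — 2020 nM
compound 2 `Oc1ccccc1CNc1ccc(-c2cccc(Cl)c2)cc1` — 6200 nM
compound 3 `COc1cccc(-c2ccc(NCc3ccccc3O)cc2)c1` — "not active" (no number reported)

Within the data shown here, in a functional assay on Jurkat cells (Homo sapiens) for activation, with a stated time of 24 h (on this read-out higher numbers stand for an effect only at larger amounts of compound and lower numbers for an effect already at smaller amounts), compound 1 gives 2020 nM and compound 2 gives 6200 nM; the only measured step is a 3.1-fold higher number from compound 1 to compound 2 (0.49 log units; beyond the scatter). Compound 3 stands apart from both: in this assay compound 3 is reported as "not active" (no number reported), so no number exists for it. Compound 4 `CCOc1cccc(-c2ccc(NCc3ccccc3O)cc2)c1` differs from compound 3 by methyl in place of hydrogen on a saturated chain carbon bound to an oxygen on an aromatic ring. Among the measured compounds shown here, no measured step concerns this change; the step from compound 1 to compound 2 involves a different exchange and gives no guide here. Given the inactivity of compound 3, compound 4 is expected most likely to give only a limit in this assay; if a number is obtained, it is estimated at 15000 nM, within 4000 nM to 60000 nM.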

Compound 4, half-maximal effective concentration: "not active" (no number reported)
Compound 4 has no reported number here; the estimate stays without a comparison.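

Among these compounds, compound 3 and compound 4 both carry no number in this assay, so no step from methoxy to ethoxy can be read. The compounds shown leave open whether these two groups differ in effect. No supporting measurement bears on this result.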